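The source may report more compounds than this note shows. Statements on the series, on what has been measured and on what is new or still open speak of the compounds shown alone.

Of the compounds shown here, three built on one shared core have been measured in a physicochemical assay for solubility, at pH 6.9; a higher number here means a more soluble compound, a lower number a less soluble compound. Compound 1 `O=C(CN1CCN(c2cc3c(cc2F)c(=O)c(C(=O)O)cn3C2CC2)CC1)Nc1ccc(C(=O)/C=C/c2ccccc2)cc1` gives 2.73 ug/mL. Compound 2 `O=C(CN1CCN(c2cc3c(cc2F)c(=O)c(C(=O)O)cn3C2CC2)CC1)Nc1ccc(C(=O)/C=C/c2cccc(Cl)c2)cc1` gives 34.4 ug/mL. Compound 3 `O=C(CN1CCN(c2cc3c(cc2F)c(=O)c(C(=O)O)cn3C2CC2)CC1)Nc1ccc(C(=O)/C=C/c2ccc(Cl)cc2)cc1` gives 2.77 ug/mL, the second highest of the three numbers; its nearest neighbour is compound 1, the two lying within the scatter of each other, while compound 2 is furthest away, as a 12-fold lower number from compound 2 to compound 3 (1.09 log units; beyond the scatter) shows. Compound 4 `COc1cc(/C=C/C(=O)c2ccc(NC(=O)CN3CCN(c4cc5c(cc4F)c(=O)c(C(=O)O)cn5C4CC4)CC3)cc2)cc(OC)c1OC` is not yet measured and differs from compound 3 in one place: 3,4,5-trimethoxyphenyl in place of 4-chlorophenyl on a double-bonded chain carbon bound to a double-bonded chain carbon. Within the data shown here, three measured steps touch the same place on the chain. a 13-fold higher number from compound 1 to compound 2 (1.10 log units; beyond the scatter) and a 1.0-fold higher number from compound 1 to compound 3 (0.01 log units; within the scatter) show that adding a chloro to this ring can move the number a great deal or not at all, and a 12-fold lower number from compound 2 to compound 3 (1.09 log units; beyond the scatter) shows the large gap between the two chlorophenyl groups. Among the measured compounds shown here, no measured step involves methoxy groups, so the direction is uncertain; the entering group carries hydrogen-bond acceptors where the chlorophenyl had none, and a modest rise seems the more likely outcome. Compound 4 is therefore expected to give 8 ug/mL, with a range from 2 ug/mL to 40 ug/mL. That estimate means an expected step of a 2.9-fold higher number from compound 3 to compound 4 (0.46 log units; beyond the scatter).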

Compound 4, solubility: 2.13 ug/mL
The estimate for compound 4 lay 3.8-fold (0.57 log units) above the measured number, and the stated range covers the measured number.
By their numbers in this assay, from the lowest: compounds 4, 1 and 3 (each within the scatter of the next); then compound 2.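

In this assay, 3,4,5-trimethoxyphenyl on this double-bonded chain carbon gives a number that stays level with both the plain phenyl, a 1.3-fold lower number from compound 1 to compound 4 (0.11 log units; within the scatter), and the 4-chlorophenyl, a 1.3-fold lower number from compound 3 to compound 4 (0.11 log units; within the scatter). A larger group carrying hydrogen-bond acceptors therefore leaves the number where it was, and the 3-chlorophenyl now stands apart from a second kind of ring, a 16-fold lower number from compound 2 to compound 4 (1.21 log units; beyond the scatter). Nothing available here explains why that one ring differs from the others.

As far as these compounds go, it stays open whether the high number of compound 2 is particular to 3-chlorophenyl or would also come with a fluoro, a methyl or an amine on the ring. Also open, from the compounds shown here alone, is whether a carboxylic acid on the ring, or a longer chain in its place, would lift the number above the level shared by compound 1, compound 3 and compound 4.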